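Removing a Methoxy Group from an Anticonvulsant Amide

A few compounds are considered here, and "the series" means these few. Any claim that something is new, unique, unknown or untested is made for them only; others in the source may bear on it.

Three compounds sharing one core were tested in a functional assay on the whole organism (strain Swiss) with Mus musculus as the target, in the maximal electroshock model, with a stated time of 0.5 h, at a dose of 300 mg/kg by the intraperitoneal route; a lower number here means a weaker effect, a higher number a stronger effect of the compound at the dose given. Compound 1 `COCC(C(=O)N1CCN(c2cccc(C(F)(F)F)c2)CC1)N1C(=O)CCC1=O` gives 50%. Compound 2 `CC(C(=O)N1CCN(c2ccccc2F)CC1)N1C(=O)CCC1=O` gives 50%, level with compound 1 within the scatter, so the two together hold the highest of the three numbers. Compound 3 `CCC(C(=O)N1CCN(c2ccc(F)cc2)CC1)N1C(=O)CCC1=O` gives 25%, a number that lies beyond the scatter below compound 1 and makes compound 3 its furthest neighbour. Compound 4 `CC(C(=O)N1CCN(c2cccc(C(F)(F)F)c2)CC1)N1C(=O)CCC1=O` has not yet been tested. It differs from compound 1 by hydrogen in place of methoxy on a saturated chain carbon, two bonds along the chain from an amide-type nitrogen in a ring and a carbonyl carbon. Within the data shown here, no step between two measured compounds makes this exact change. The step of no change at the digits printed from compound 1 to compound 4 (within the scatter) is expected to stay within the scatter, in no clear direction. Compound 4 is therefore estimated at 50%, with a range from 25% to 75%.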

Compound 4, a percentage reported as activity, at one dose (the size of the read-out at that dose, not a potency): 100%
Estimate against measurement, compound 4: 50 percentage points below, outside the stated range (above it).
By their numbers in this assay, from the lowest: compound 3; then compounds 1 and 2 (each within the scatter of the next); then compound 4.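

In this assay, among these compounds, the change gives the first readable step at this position: hydrogen in place of methoxy on this saturated chain carbon brings a number 50 percentage points higher from compound 1 to compound 4 (beyond the scatter). This position is therefore not indifferent to what it carries, and here the smaller methyl end of the chain goes with the stronger effect at this dose. No measurement on hand explains this change.

Still open, as far as these compounds go, is how a hydroxymethyl group or an amine on this carbon would read out. A single pair also cannot show whether the same change behaves alike elsewhere in the series.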